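Replacing a Phenoxy Group by an Arylamino Group

The compounds below may be only part of what the source reports. "The series", "measured", "known", "first", "only" and "open" are said of these compounds alone.

Measured compounds:
- compound 1 `CC1(C)Oc2ccc(C#N)cc2[C@@H](/N=C(\NC#N)Oc2ccccc2)[C@@H]1O`, > 100000 nM
- compound 2 `CC1(C)Oc2ccc(C#N)cc2[C@@H](NC(=O)Nc2cccnc2)[C@@H]1O`, 500 nM

Both compounds were tested in a functional assay (aorta) with Rattus norvegicus as the target; a lower number here means a stronger inhibitor, a higher number a weaker inhibitor. Compound 1 gives only a limit in this assay, namely > 100000 nM, so no number is known for it; the shown evidence states this as the limit of > 100000 nM in this assay, at which 1 of the 2 values shown sits. In place of the cyanoguanidine of compound 1, compound 2 carries a urea linked to a pyridine; compound 2 gives 500 nM in this assay, a clear measurable value. Among the measured compounds shown here, no step between two measured compounds that differ in a single place is available, so nothing can be said about the size of any single structural change from these two alone.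

Compound 3 `CC1(C)Oc2ccc(C#N)cc2[C@@H](/N=C(\NC#N)Nc2ccc3c(c2)CCC3)[C@@H]1O` has not yet been measured. It differs from compound 1 as follows: (2,3-dihydro-1H-inden-5-yl)amino in place of phenoxy on a carbon with a double bond to nitrogen. The expectation is that the step of an at least 100-fold lower number from compound 1 to compound 3 (2.00 log units; beyond the scatter) brings compound 3 well inside the measurable range, towards the region where compound 2 sits at 500 nM, since that compound shows that the shared core can give a measurable value. Compound 3 is therefore expected to reach about 1000 nM in this assay, with a plausible range from 100 nM to 10000 nM.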

Compound 3, half-maximal inhibitory concentration: 41300 nM
Compound 3: middle estimate off by 41-fold (1.62 log units), on the low side; the whole stated range lies below it.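

Swapping phenoxy for (2,3-dihydro-1H-inden-5-yl)amino on a carbon with a double bond to nitrogen gives, in this assay, an at least 2.4-fold lower number from compound 1 to compound 3 (0.38 log units; beyond the scatter), so a change at this one position is enough to give a measured value while the rest of the molecule stays the same. In this comparison, compound 1 gives > 100000 nM, which is a limit of the assay and not a number, so the step has a known minimum size but no known true size. The change also alters two things at once, since an amine nitrogen carrying a hydrogen-bond donor replaces the oxygen and a five-membered non-aromatic ring is added to the six-membered aromatic ring, and the step cannot be divided between them.

The compounds shown leave open which of these two differences matters, and a plain phenylamino group at the same place would separate the nitrogen from the added ring. They also leave open how a small alkylamino group, such as methylamino, or a longer chain on that nitrogen would compare.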